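This account rests on a few compounds, and the source may have more. Where it says the series, first, only, none or still open, it means among the compounds named here.

Measured so far in a functional assay on MCF7 cells (Homo sapiens) for inhibition, read by MTT assay, with a stated time of 72 h; on this read-out higher numbers stand for weaker inhibition and lower numbers for stronger inhibition:
- compound 1, `CCCc1ccc(NC(=O)C2CCN(C/C=C/c3ccccc3)CC2)cc1`: 9030 nM
- compound 2, `O=C(Nc1nc2ccc(Br)cc2s1)C1CCN(C/C=C/c2ccccc2)CC1`: 14600 nM

Compound 1 has the lower of the two numbers, but the gap to compound 2 is within the scatter, so the two cannot be ranked. Going by the values given here, no step between measured compounds that differ in one place is available, so nothing on the size of any single change can be read from these two.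

Compound 3, `O=C(NCc1ccccc1)C1CCN(C/C=C/c2ccccc2)CC1`, is not yet measured in this assay. It differs from compound 1 by benzyl in place of 4-propylphenyl on an amide-type nitrogen. Among the compounds with values here, with no comparable step to lean on, the expected step from compound 1 to compound 3 is small, at most a modest weakening, and may well stay inside the scatter: a 1.3-fold higher number from compound 1 to compound 3 (0.12 log units; within the scatter). The estimate for compound 3 in this assay is 12000 nM, with a range from 5000 nM to 30000 nM.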

Compound 3, half-maximal inhibitory concentration: > 100000 nM
Compound 3 gave a limit, no number; the forecaster's own chance of this, stated with the estimate: 10%; at least 8.3-fold (0.92 log units) between middle value and limit.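

In this assay compound 3 gives > 100000 nM, which is a limit and not a number. Benzyl in place of 4-propylphenyl on the amide-type nitrogen gives an at least 11-fold higher number from compound 1 to compound 3 (1.04 log units; beyond the scatter), so this place in the series does not accept every group that carries a six-membered aromatic ring. The full size of the step cannot be read, only its lower end: the limit of > 100000 nM in this assay, at which 1 of the 3 values shown sits.

The compounds shown leave open whether the loss goes with the methylene link of benzyl or with the missing propyl chain, since both differ in this one step. An unsubstituted phenyl on the same nitrogen would separate the two, and a benzyl carrying a propyl chain would test the same question from the other side.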